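Chloro to bromo exchange in the quinolone hydroxamic acid pair

The source may hold more compounds than are shown below. What is called first, only, known or untested is meant among the compounds shown, and "the series" means these compounds.

Measured compounds:
compound 1 `O=C(O)c1cn(Cc2ccc(Cl)cc2)c2ccccc2c1=O`, 28.7%
compound 2 `O=C(O)c1cn(Cc2ccc(Br)cc2)c2ccccc2c1=O`, 25.4%
compound 3 `O=C(NO)c1cn(Cc2ccc(Cl)cc2)c2ccccc2c1=O`, 31.7%

In a functional assay, tested at 100 uM (a higher number here means a stronger effect of the compound at the concentration tested, a lower number a weaker effect), compound 1 gives 28.7%, compound 2 gives 25.4% and compound 3 gives 31.7%. The three numbers sit close together: the gap from compound 1 to compound 3 is a number 3 percentage points higher from compound 1 to compound 3 (within the scatter), and the gap from compound 2 to compound 3 is within the scatter as well, so compound 3 cannot be set apart from either.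

Compound 4 `O=C(NO)c1cn(Cc2ccc(Br)cc2)c2ccccc2c1=O` is not yet measured. Its change from compound 3 is bromo in place of chloro on an aromatic carbon. The same exchange has been seen once before, on the acid pair: a number 3.3 percentage points lower from compound 1 to compound 2 (within the scatter), a step within the scatter. On that basis no step beyond the scatter is expected in this assay for compound 4, with at most a slight drift downward.

The expected step from compound 3 is a number 3.2 percentage points lower from compound 3 to compound 4 (within the scatter). Compound 4 is therefore estimated at 28.5%, within a range from 18% to 39%.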

Compound 4, a percentage reported as activity, at one concentration (the size of the read-out at that concentration, not a potency): 27.6%
Compound 4: middle estimate off by 0.9 percentage points, on the high side, and the stated range covers the measured number.
By their numbers in this assay, from the lowest: compounds 2, 4, 1 and 3 (each within the scatter of the next).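

With compound 4, the exchange of 4-chlorophenyl for 4-bromophenyl can be read on a second core in this assay, as a number 4.1 percentage points lower from compound 3 to compound 4 (within the scatter), and the two readings agree: the same change on two cores in this assay, a number 3.3 percentage points lower (within the scatter) from compound 1 to compound 2 and a number 4.1 percentage points lower (within the scatter) from compound 3 to compound 4, 0.8 percentage points apart, within the scatter of two such steps

The change from hydroxy to hydroxyamino on the carbonyl carbon, previously read only with chloro in place, now has a reading with bromo, a number 2.2 percentage points higher from compound 2 to compound 4 (within the scatter), and it also repeats: the same change on two cores in this assay, a number 3 percentage points higher (within the scatter) from compound 1 to compound 3 and a number 2.2 percentage points higher (within the scatter) from compound 2 to compound 4, 0.8 percentage points apart, within the scatter of two such steps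

Across these four compounds, neither change shifts the size of the other beyond the scatter, and no step printed for them leaves the scatter.

Only chloro and bromo are shown at this place on the aromatic ring, so whether a methoxy group or an amine there would give a step beyond the scatter stays open. A read-out at one concentration also gives no potency for any of the four compounds.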